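A longer chain on compound 3

This account rests on a few compounds, and the source may have more. Where it says the series, first, only, none or still open, it means among the compounds named here.

compound 1 `COc1cc2ncnc(-n3nc(-c4ccccn4)nc3N)c2cc1OCCCN(C)C` gives > 25000 nM as a limit
compound 2 `COc1cc2ncnc(-n3nc(-c4ccccn4)nc3N)c2cc1OCCCN1CC(C)OC(C)C1` gives > 25000 nM as a limit
compound 3 `COc1cc2ncnc(-n3nc(-c4ccccn4)nc3N)c2cc1OCCCNC(=O)OC(C)(C)C` gives > 12000 nM as a limit

In an ADME assay on BJ cells (Homo sapiens) for cytotoxicity, with a stated time of 72 h (a lower number here means that less compound is needed, a higher number that more compound is needed for the effect), compound 3 gives > 12000 nM as a limit and not a number. All three measured compounds stop at a limit, so no number places compound 3 against the others. Compound 4 `COc1cc2ncnc(-n3nc(-c4ccccn4)nc3N)c2cc1OCCCCNC(=O)OC(C)(C)C` differs from compound 3 as set out in ((tert-butoxycarbonyl)amino)methyl in place of (tert-butoxycarbonyl)amino on a saturated chain carbon, three bonds along the chain from an oxygen on an aromatic ring with ((tert-butoxycarbonyl)amino)methyl in place of (tert-butoxycarbonyl)amino on a saturated chain carbon, three bonds along the chain from an oxygen on an aromatic ring. At this same place the measurements offer a step that the two limits leave unreadable from compound 1 to compound 2 and a step that the two limits leave unreadable from compound 1 to compound 3 and a step that the two limits leave unreadable from compound 2 to compound 3 and none of these has a readable size. What remains is the limit of > 25000 nM in this assay, at which 2 of the 3 values shown sit, and the limit of > 12000 nM in this assay, at which 1 of the 3 values shown sits, with no number anywhere. No step beyond the scatter is therefore expected in this assay in either direction. The step expected is a step that the limit leaves unreadable from compound 3 to compound 4 in this estimate. Compound 4 is expected at 18000 nM in an estimated range from 9000 nM to 36000 nM and it may well end at a limit again.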

Compound 4, half-maximal effective concentration: > 7000 nM
Compound 4 was reported as a limit; the forecaster's own chance of this, stated with the estimate: 85%; the middle value does not contradict the limit.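

Going by these compounds alone, compound 4 stops at a limit in this assay, as do compound 1, compound 2 and compound 3, so no step from any of them to compound 4 can be read. The compounds shown leave open whether the longer chain of compound 4 changes the concentration needed at all, in either direction.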